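Methoxy shift on a sulfonamide seeking Nrf2 activation

The source may report more compounds than this note shows. Statements on the series, on what has been measured and on what is new or still open speak of the compounds shown alone.

Compound 1 `O=S(=O)(/C=C/c1ccccc1)Nc1ccccc1` gives in an assay on U2OS cells for activation of nuclear factor erythroid 2-related factor 2 (Homo sapiens), read by chemiluminescence, with a stated time of 6 h (a lower number here means that less compound is needed, a higher number that more compound is needed for the effect), the value > 10000 nM, a limit of the assay.
Compound 2 `O=S(=O)(/C=C/c1ccccc1Cl)Nc1ccccc1` gives in this assay the value > 10000 nM, also a limit.
Compound 3 `COc1cccc(NS(=O)(=O)/C=C/c2ccccc2Cl)c1` gives in this assay the value > 10000 nM, again a limit.

Compound 2 stands where every measured compound stands: at the limit of > 10000 nM in this assay, at which 3 of the 3 values shown sit, so no number separates it from compound 1 or compound 3. The step that the two limits leave unreadable from compound 1 to compound 2 has no readable size, and the same holds for a step that the two limits leave unreadable from compound 2 to compound 3.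

Compound 4 `COc1ccc(NS(=O)(=O)/C=C/c2ccccc2Cl)cc1` differs from compound 2 by methoxy in place of hydrogen on an aromatic carbon. Among the compounds with values here, the one measured step that bears on it is the addition of methoxy on the same kind of aromatic carbon, a step that the two limits leave unreadable from compound 2 to compound 3, and that step could not be read. Within the data shown here, with no measured step showing a direction, the expectation for compound 4 is the one the measured compounds already share: a step that the limit leaves unreadable from compound 2 to compound 4 that is expected to stay within the scatter, leaving compound 4 most likely at the limit again. Compound 4 is estimated at 20000 nM, ranging from 5000 nM to 100000 nM.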

Compound 4, half-maximal effective concentration: > 10000 nM
Compound 4: only a limit was reported (the forecaster's own chance of this, stated with the estimate: 85%); the middle value does not contradict the limit.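

Within the data shown here, compound 2 and compound 4 both sit at a limit of the assay, so no step between them can be read: the limit of > 10000 nM in this assay, at which 4 of the 4 values shown sit.

In this assay the compounds shown leave open which change to the shared core, if any, would give a value that is a real number rather than a limit.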